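The source may hold more compounds than are shown below. What is called first, only, known or untested is meant among the compounds shown, and "the series" means these compounds.

The compounds measured so far in a functional assay on Huh-7 cells (Homo sapiens) for cytotoxicity, read by MTT assay, with a stated time of 3 days; a higher number here means that more compound is tolerated, a lower number that less compound is tolerated:
compound 1 `CN(Cc1ccccc1)Cc1ncnc2c1ncn2[C@@H]1O[C@H](CO)[C@@H](O)[C@H]1O`, 9000 nM.
Compound 2 `O=c1ccccn1Cc1ncnc2c1ncn2[C@@H]1O[C@H](CO)[C@@H](O)[C@H]1O`, which reached only a limit of the assay, > 100000 nM.
Compound 3 `CSCc1ncnc2c1ncn2[C@@H]1O[C@H](CO)[C@@H](O)[C@H]1O`, which also reached only a limit of the assay, > 100000 nM.

Going by the values given here, compound 1 thus stands as the only actual number among the three; the other two values are limits. Compound 4 `O=c1ccn(Cc2ncnc3c2ncn3[C@@H]2O[C@H](CO)[C@@H](O)[C@H]2O)cc1` differs from compound 1 as follows: a group of 7 heavy atoms (5 carbon, 1 nitrogen, 1 oxygen; one six-membered aromatic ring with 1 hetero atom) in place of a group of 9 heavy atoms (8 carbon, 1 nitrogen; one six-membered aromatic ring of carbon only), on a saturated chain carbon bound to an aromatic carbon. The step that bears most directly on this change is an at least 11-fold higher number from compound 1 to compound 2 (1.04 log units; beyond the scatter), a change of the same kind at the same place, and an at least 11-fold higher number from compound 1 to compound 3 (1.04 log units; beyond the scatter) points the same way; both end at the limit of > 100000 nM in this assay, at which 2 of the 3 values shown sit. A large upward step in this assay is therefore expected for compound 4, namely an 11-fold higher number from compound 1 to compound 4 (1.05 log units; beyond the scatter), most likely ending again at a limit. Compound 4 is estimated at 100000 nM, with a range from 40000 nM to 300000 nM.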

Compound 4, half-maximal cytotoxic concentration: > 100000 nM
Compound 4 gave a limit, no number (the forecaster's own chance of this, stated with the estimate: 70%); the middle value sits exactly at the limit.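

In this assay, the change on the saturated chain carbon bound to an aromatic carbon gives an at least 11-fold higher number from compound 1 to compound 4 (1.04 log units; beyond the scatter), so a second group of the same composition as in compound 2 repeats that step. The steps among compound 2, compound 3 and compound 4 cannot be read, so these compounds cannot be ranked. Most of the values now rest on one limit: the limit of > 100000 nM in this assay, at which 3 of the 4 values shown sit.

As far as these compounds go, it remains open whether the lower number of compound 1 goes with its benzyl ring or its amine nitrogen. A dimethylamino group or a plain benzyl group at this place would separate the two.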